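The source may hold more compounds than are shown below. What is called first, only, known or untested is meant among the compounds shown, and "the series" means these compounds.

Working notes on the series.

Compound 1 `Cn1c(COc2cccc(C(=O)O)c2)nc2ccc(Oc3ccc(Cl)c(F)c3)nc21` and compound 3 `Cn1c(COc2cccc(C(=O)O)c2)nc2cnc(Oc3ccc(Cl)c(F)c3)cc21` share the same atoms joined differently; the difference between the two cores is not broken down here. Both carry a 4-chloro-3-fluorophenyl on an oxygen on an aromatic ring. In a physicochemical assay for lipophilicity, read by LC-MS, in phosphate buffer, measured as octanol-water partition, with a stated time of 30 min, at pH 7.4, tested at 200 mM (on this read-out higher numbers stand for higher lipophilicity and lower numbers for lower lipophilicity), compound 1 gives 2.2, and in this assay compound 3 gives 1.4, the lowest number among the three measured compounds.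

Compound 2 `Cc1ccc(Oc2ccc3nc(COc4cccc(C(=O)O)c4)n(C)c3n2)cc1` is the partner of compound 1 with the change (4-methylphenyl in place of 4-chloro-3-fluorophenyl on an oxygen on an aromatic ring). In this assay compound 2 gives 1.7. The step of a number 0.50 log units lower from compound 1 to compound 2 (beyond the scatter) is a modest drop, beyond the scatter. The value of compound 2 and that of compound 3 lie within the scatter of each other, so no order between them is claimed.

Compound 4 `Cc1ccc(Oc2cc3c(cn2)nc(COc2cccc(C(=O)O)c2)n3C)cc1` is not yet measured. It relates to compound 3 by the change (4-methylphenyl in place of 4-chloro-3-fluorophenyl on an oxygen on an aromatic ring), the same change already seen between compound 1 and compound 2, with the same surroundings at the place of exchange. This change has been observed only once in the set, so the expectation rests on a single pair.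

For compound 4 in this assay the step of a number 0.50 log units lower from compound 3 to compound 4 (beyond the scatter) is expected to match the earlier drop, because compound 1 to compound 2 gave a number 0.50 log units lower from compound 1 to compound 2 (beyond the scatter). Compound 4 is therefore estimated at 0.9 in this assay, with a likely range from 0.5 to 1.3.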

Compound 4, distribution coefficient: 1
Compound 4: the middle estimate sits 0.10 log units below what was measured, and the stated range covers the measured number.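

The exchange of 4-chloro-3-fluorophenyl for 4-methylphenyl on an oxygen on an aromatic ring now has two readings in this assay: on the second core it gives a number 0.40 log units lower from compound 3 to compound 4 (beyond the scatter) and on the first core it gives a number 0.50 log units lower from compound 1 to compound 2 (beyond the scatter). For the compounds shown here, both steps run in the same direction and both are modest, so within these two pairs the change carries from one core to the other, and no compound in the set goes against this. Going by these compounds alone, this is still only two pairs on two cores with the same atoms joined differently, so it does not show that the change would carry to any further core, and nothing available explains the drop in either pair.

The compounds shown leave open whether other groups on the same oxygen, such as a phenyl bearing a nitrile or a trifluoromethyl, would shift the number by a similar amount on both cores. They also leave open whether the two steps would still agree with an amine or an amide in place of the carboxylic acid.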